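This account rests on a few compounds, and the source may have more. Where it says the series, first, only, none or still open, it means among the compounds named here.

In a functional assay on OVCAR cells (Homo sapiens) for cytotoxicity, read by sulforhodamine B assay, with a stated time of 48 h (a higher number here means a weaker inhibitor, a lower number a stronger inhibitor), compound 2 `COc1ccc(C2CC(c3ccco3)=NN2C(C)=O)cc1` gives 14300 nM, and compound 1 `CC(=O)N1N=C(c2ccccc2)CC1c1ccc(N(C)C)cc1` gives 12000 nM; the two numbers lie within the scatter of each other, so compound 2 does not stand apart on what has been measured. Compound 3 `CC(=O)N1N=C(c2ccco2)CC1c1ccc(N(C)C)cc1` differs from compound 2 by dimethylamino in place of methoxy on an aromatic carbon. Going by the values given here, no measured pair shows the size of this exchange, so no step beyond the scatter is expected in this assay, in either direction. Compound 3 is accordingly expected at 12000 nM in this assay, within 5000 nM to 28000 nM. The expected step is a 1.2-fold lower number from compound 2 to compound 3 (0.08 log units; within the scatter).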

Compound 3, half-maximal inhibitory concentration: 14600 nM
Beside the measured number, compound 3's estimate is 1.2-fold (0.09 log units) below it; low and high end bracket the measured number.
By their numbers in this assay, from the lowest: compounds 1, 2 and 3 (each within the scatter of the next).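

In this assay, going by these compounds alone, dimethylamino in place of methoxy on an aromatic carbon gives a 1.0-fold higher number from compound 2 to compound 3 (0.01 log units; within the scatter) as the first reading of this exchange. Furan-2-yl in place of phenyl on a carbon with a double bond to nitrogen gives a 1.2-fold higher number from compound 1 to compound 3 (0.09 log units; within the scatter) and so also fails to separate the compounds. No measurement here offers an explanation for either reading. Going by these compounds, whether a carboxylic acid or a primary amine on that aromatic carbon would give a step beyond the scatter remains open. The same question stands for a longer chain in place of furan-2-yl or phenyl.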